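The source may report more compounds than this note shows. Statements on the series, on what has been measured and on what is new or still open speak of the compounds shown alone.

Measured compounds in a functional assay on CHO cells for antagonist activity at Orexin/Hypocretin receptor type 1 (Homo sapiens), read by FLIPR and calcium flux; a higher number here means a weaker inhibitor, a lower number a stronger inhibitor:
- compound 1 `Cc1ccc(C)c(NC(=O)CSc2nnc(-c3ccoc3C)n2Cc2ccco2)c1` gives > 15800 nM, which is a limit of the assay rather than a number.
- compound 2 `Cc1cccc(C)c1NC(=O)CSc1nnc(-c2ccoc2C)n1Cc1ccco1` gives > 15800 nM, likewise a limit.
- compound 3 `Cc1occc1-c1nnc(SCC(=O)Nc2ccc(Cl)cc2)n1Cc1ccco1` gives 2000 nM.

Compound 1 thus sits at the limit of this assay the limit of > 15800 nM in this assay, at which 2 of the 3 values shown sit, and has no number of its own. Compound 2 sits at the same limit. Only compound 3 yields a measured value.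

Compound 4 `Cc1occc1-c1nnc(SCC(=O)Nc2ccc(N(C)C)cc2)n1Cc1ccco1` differs from compound 1 by a single change: 4-(dimethylamino)phenyl in place of 2,5-dimethylphenyl on an amide-type nitrogen

Going by the values given here, two measured steps bear on this change. Both replace a dimethylphenyl by 4-chlorophenyl on the amide-type nitrogen: an at least 7.9-fold lower number from compound 1 to compound 3 (0.89 log units; beyond the scatter) and an at least 7.9-fold lower number from compound 2 to compound 3 (0.89 log units; beyond the scatter). Moving from a dimethylphenyl to a phenyl carrying one group therefore brought the number down out of the limit. Compound 4 likewise carries one group on its phenyl, as 4-(dimethylamino)phenyl, yet a dimethylamino group is not a chloro group, so the size of the step cannot be read from compound 3 alone. A downward step is expected, of uncertain size.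

Compound 4 is expected to give about 6000 nM, with a range from 1500 nM to 20000 nM. The expected step is an at least 2.6-fold lower number from compound 1 to compound 4 (0.42 log units; beyond the scatter).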

Compound 4, inhibition constant: 794 nM
For compound 4 the middle estimate is 7.6-fold (0.88 log units) above the measured one; the measured number lies below the stated range.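

In this assay, going by these compounds alone, replacing chloro with dimethylamino on this phenyl gives a 2.5-fold lower number from compound 3 to compound 4 (0.40 log units; beyond the scatter), so the identity of the single group matters, not merely the removal of the two methyl groups. Measured against the dimethylphenyl compounds, the change is larger: an at least 19-fold lower number from compound 1 to compound 4 (1.29 log units; beyond the scatter) and an at least 19-fold lower number from compound 2 to compound 4 (1.29 log units; beyond the scatter). Both of these steps start from a limit of the assay, not from a measured number, so their true size may be greater: the limit of > 15800 nM in this assay, at which 2 of the 4 values shown sit.

The compounds shown do not reveal how plain phenyl, 4-methylphenyl or 4-methoxyphenyl would compare with 4-(dimethylamino)phenyl at this amide-type nitrogen. Going by these compounds, all four compounds also share the same core, and whether the same order of groups holds on a different core remains open.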